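Two chlorines in place of a trifluoromethyl on an aryl urea

The source may hold more compounds than are shown below. What is called first, only, known or untested is meant among the compounds shown, and "the series" means these compounds.

Compound 1 `COc1cc2cc(Oc3ccc(NC(=O)Nc4cccc(C(F)(F)F)c4)cc3)c(C)nc2cc1OC` is the starting point. Within the data shown here, in a functional assay on OVCAR-4 cells (Homo sapiens) for inhibition, read by sulforhodamine B assay, with a stated time of 48 h, tested at 10 uM (a higher number here means a weaker effect of the compound at the concentration tested, a lower number a stronger effect), compound 1 gives 31.7%, the highest of the two numbers measured so far, which here means the weaker effect. Compound 2 `COc1cc2cc(Oc3ccc(NC(=O)Nc4ccc(Cl)c(C(F)(F)F)c4)cc3)c(C)nc2cc1OC` differs from it by chloro in place of hydrogen on an aromatic carbon, and in this assay compound 2 gives 17.1%; the step of a number 14.6 percentage points lower from compound 1 to compound 2 (beyond the scatter) is the only measured one. Compound 3 `COc1cc2cc(Oc3ccc(NC(=O)Nc4ccc(Cl)c(Cl)c4)cc3)c(C)nc2cc1OC` has not yet been measured. Its change from compound 1 is 3,4-dichlorophenyl in place of 3-(trifluoromethyl)phenyl on an amide-type nitrogen. Among the measured compounds shown here, the measured step bears on this only in part: compound 3 keeps the chlorine that compound 2 carries but exchanges the trifluoromethyl for a second chlorine, and no measured pair shows that exchange. A downward step of roughly the size seen in the measured pair is therefore expected, with wide uncertainty. For compound 3 a value of 20% is estimated, between 8% and 36%, which would be a step of a number 11.7 percentage points lower from compound 1 to compound 3 (beyond the scatter).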

Compound 3, a percentage reported as activity, at one concentration (the size of the read-out at that concentration, not a potency): 31.9%
For compound 3 the middle estimate is 11.9 percentage points below the measured one, within the range that was stated.
By their numbers in this assay, from the lowest: compound 2; then compounds 1 and 3 (each within the scatter of the next).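

In this assay, chloro in place of trifluoromethyl on an aromatic carbon gives a number 14.8 percentage points higher from compound 2 to compound 3 (beyond the scatter), so the stronger effect of compound 2 does not survive the loss of its trifluoromethyl. Exchanging the whole ring, 3,4-dichlorophenyl in place of 3-(trifluoromethyl)phenyl on an amide-type nitrogen, gives a number 0.2 percentage points higher from compound 1 to compound 3 (within the scatter), so this exchange brings no readable difference. Among these compounds, then, the added chlorine goes with a stronger effect only when the trifluoromethyl stays, and no measurement is available to explain why.

As far as these compounds go, it remains open whether a different group in place of that trifluoromethyl, such as a nitrile, a methyl or a methoxy, would hold the stronger effect. A ring carrying a single chlorine would also show what that chlorine does without the trifluoromethyl.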